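A Hydroxyl Shift Tested on Two Related Cores

The compounds below may be only part of what the source reports. "The series", "measured", "known", "first", "only" and "open" are said of these compounds alone.

Compound 1 `Oc1cccc(-c2cc(-c3cccs3)cc(-c3ccccc3O)n2)c1` gives 9300 nM in a functional assay on DU-145 cells (Homo sapiens) for cytotoxicity, read by CCK-8 assay; on this read-out lower numbers stand for stronger inhibition and higher numbers for weaker inhibition. Compound 2 `Oc1cccc(-c2cc(-c3cccs3)cc(-c3cccc(O)c3)n2)c1` gives 1630 nM in this assay. The change from compound 1 to compound 2 is 3-hydroxyphenyl in place of 2-hydroxyphenyl on an aromatic carbon, and it produced a 5.7-fold lower number from compound 1 to compound 2 (0.76 log units; beyond the scatter).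

Compound 3 `Oc1ccccc1-c1cc(-c2ccco2)cc(-c2ccccc2O)n1` is known only as a limit of this assay, at > 50000 nM. This is the limit of > 50000 nM in this assay, at which 1 of the 3 values shown sits, and nothing more than the limit is known for compound 3. How the core of compound 3 differs from the core of compound 1 is not broken down here.

Compound 4 `Oc1cccc(-c2cc(-c3ccco3)cc(-c3ccccc3O)n2)c1` has not yet been measured. Its difference from compound 3 is 3-hydroxyphenyl in place of 2-hydroxyphenyl on an aromatic carbon. Among the compounds with values here, this is the same kind of change as the one from compound 1 to compound 2, but the surroundings differ: in compound 1 the place is meta to a 3-hydroxyphenyl group and meta to a thiophen-2-yl group, whereas in compound 3 it is meta to a 2-hydroxyphenyl group and meta to a furan-2-yl group.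

The step expected here is an at least 1.6-fold lower number from compound 3 to compound 4 (0.22 log units; that floor lies within the scatter), set beside the measured 5.7-fold lower number from compound 1 to compound 2 (0.76 log units; beyond the scatter), and it rests on that single earlier step only. The limit for compound 3 leaves the starting point uncertain, so the expectation is wide. For compound 4 the estimated value in this assay is 30000 nM, with an expected range from 8000 nM to 100000 nM.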

Compound 4, half-maximal inhibitory concentration: 1790 nM
For compound 4 the middle estimate is 17-fold (1.22 log units) above the measured one; the whole stated range lies above it.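

The change from 2-hydroxyphenyl to 3-hydroxyphenyl carried over in direction, giving an at least 27-fold lower number from compound 3 to compound 4 (1.44 log units; beyond the scatter), but it did not carry over in size, as the two steps differ: the same change on two cores in this assay, a 5.7-fold lower number (0.76 log units; beyond the scatter) from compound 1 to compound 2 and an at least 27-fold lower number (1.44 log units; beyond the scatter) from compound 3 to compound 4, at least 4.8-fold (0.68 log units) apart, beyond the scatter of two such steps

The size of the second step is only a floor, as compound 3 stands at a limit of the assay: the limit of > 50000 nM in this assay, at which 1 of the 4 values shown sits.

The two cores themselves differ by furan-2-yl in place of thiophen-2-yl, which gives a 5.2-fold lower number from compound 1 to compound 4 (0.72 log units; beyond the scatter), and this pair of cores does not show how the hydroxyl change would behave on any further core, nor why its size differs between them.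

The compounds shown leave open how a counterpart of compound 2 with furan-2-yl in place of thiophen-2-yl, carrying two 3-hydroxyphenyl groups, would read in this assay, and so whether the second 2-hydroxyphenyl group would follow the same course on that core. Also open, going by these compounds, is how a methoxy group or an amine in place of the hydroxyl, or a plain phenyl in place of the furan-2-yl or thiophen-2-yl group, would read in this assay.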